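The compounds below may be only part of what the source reports. "The series", "measured", "known", "first", "only" and "open" are said of these compounds alone.

Working notes on the series. Compound 2 `Cn1cnnc1SCC(=O)N/N=c1/scc(-c2ccc(C#N)cc2)n1-c1ccccc1` and compound 1 `Cc1nnc(SCC(=O)N/N=c2/scc(-c3ccccc3)n2-c2ccccc2)s1` share the acylhydrazone-linked thiazoline core and differ in the heteroaryl thioether and in the aryl group on the thiazoline ring. In a functional assay on C6 cells (Rattus norvegicus) for cytotoxicity, read by MTT assay, with a stated time of 24 h, tested at 6 ug/mL (a lower number here means a stronger effect, a higher number a weaker effect of the compound at the concentration tested), compound 1 gives 72.4% and, in the same test, compound 2 gives 70.2%. The two numbers lie within the scatter of each other, so no order between compound 1 and compound 2 can be read from them; compound 2 is simply the one with the smaller of two numbers that cannot be told apart.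

Compound 3 `Cn1cnnc1SCC(=O)N/N=c1/scc(-c2ccccc2)n1-c1ccccc1` is not yet measured in this assay. Among the compounds with values here, it arises from compound 2 by the change (hydrogen in place of cyano on an aromatic carbon), which carries the aryl group of compound 2 over to the one found in compound 1 while keeping the thioether of compound 2. Within the data shown here, with only two numbers at hand, and those two indistinguishable, the step from compound 2 to compound 3 is expected to stay within the scatter, as a number 1.3 percentage points higher from compound 2 to compound 3 (within the scatter). Compound 3 is therefore estimated at 71.5%, with a range from 60% to 83%.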

Compound 3, a percentage reported as activity, at one concentration (the size of the read-out at that concentration, not a potency): 90%
The estimate for compound 3 lay 18.5 percentage points below the measured number, and the stated range ends below it.
By their numbers in this assay, from the lowest: compounds 2 and 1 (each within the scatter of the next); then compound 3.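

In this assay the aryl group matters: hydrogen in place of cyano on the aromatic carbon, the change from 4-cyanophenyl to phenyl, gives a number 19.8 percentage points higher from compound 2 to compound 3 (beyond the scatter) and so a weaker effect at the concentration tested, with the 4-methyl-4H-1,2,4-triazol-3-yl thioether held fixed. The group on the sulfur matters as well, since with phenyl held fixed 4-methyl-4H-1,2,4-triazol-3-yl in place of 5-methyl-1,3,4-thiadiazol-2-yl gives a number 17.6 percentage points higher from compound 1 to compound 3 (beyond the scatter) and the effect again weakens; the two earlier compounds differ in both places, so their indistinguishable numbers could not show either step alone. Nothing at hand gives a reason for either step.

The compounds shown leave open whether the cyano step carries over to the 5-methyl-1,3,4-thiadiazol-2-yl thioether, so it cannot yet be said whether the two places act independently. They also leave open how an amine, a carboxylic acid or a methoxy group on the same aromatic carbon would compare with cyano and hydrogen.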